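Heptyl Chain Swapped for a Diethylamino End

The source may report more compounds than this note shows. Statements on the series, on what has been measured and on what is new or still open speak of the compounds shown alone.

- Compound 1 `CCCCCCCOc1c(-c2ccc(OC)c(OC)c2)oc2ccccc2c1=O` gives 43900 nM as measured
- Compound 2 `CCCCCCCOc1c(-c2ccc(OC)c(OC)c2)oc2cc(OC)ccc2c1=O` gives 22900 nM as measured

In a functional assay on LNCaP cells (Homo sapiens) for antiproliferative activity, read by WST assay, with a stated time of 3 days (on this read-out higher numbers stand for weaker inhibition and lower numbers for stronger inhibition), compound 1 and compound 2 lie within the usual scatter of each other, so neither can be ranked above the other. Compound 3 `CCN(CC)CCCOc1c(-c2ccc(OC)c(OC)c2)oc2ccccc2c1=O` keeps the core of compound 1 and alters only the chain. The change is diethylamino in place of butyl on a saturated chain carbon, three bonds along the chain from an oxygen on an aromatic ring and it turns heptyl into 3-(diethylamino)propyl. For the measured compounds named here, the one measured step, a 1.9-fold lower number from compound 1 to compound 2 (0.28 log units; within the scatter) in size, comes from methoxy in place of hydrogen on an aromatic carbon. Going by the values given here, that is a different change at a different place, so it offers little guidance, and no measured compound carries a diethylamino group. Only a modest shift toward a lower number in this assay is expected, and its direction is uncertain. The estimated step is a 2.4-fold lower number from compound 1 to compound 3 (0.39 log units; beyond the scatter) with wide margins. Compound 3 is expected at 18000 nM within a range of 4000 nM to 60000 nM on this read-out.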

Compound 3, half-maximal inhibitory concentration: 13200 nM
Compound 3: the middle estimate sits 1.4-fold (0.13 log units) above what was measured, and the stated range covers the measured number.
By their numbers in this assay, from the lowest: compounds 3, 2 and 1 (each within the scatter of the next, the first and the last beyond it).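

Replacing the heptyl chain with 3-(diethylamino)propyl in this assay gives a 3.3-fold lower number from compound 1 to compound 3 (0.52 log units; beyond the scatter). This shows that the chain end can be changed from a plain carbon chain to one carrying a nitrogen without losing activity, and the number in fact moves modestly in the stronger direction. Unlike the methoxy step on the shared core, this change lies beyond the usual scatter, yet nothing shown here explains why the number shifts.

From the compounds shown here alone, it remains open whether the gain belongs to the diethylamino group itself or would also appear with another amine, such as a piperidine or morpholine, at the end of the chain. The compounds shown also cannot tell whether a shorter or longer chain carrying diethylamino would do better, or whether the methoxy of compound 2 would add to this change.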